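The compounds below may be only part of what the source reports. "The series", "measured", "known", "first", "only" and "open" are said of these compounds alone.

The series shares one core, and the differences lie in the group on the carbonyl carbon. Compound 1 `O=C(NCc1ccc(CNS(=O)(=O)c2ccccc2)cc1)c1ccc(F)cc1` carries a 4-fluorophenyl there, and in a functional assay on the whole organism for inhibition, with Mus musculus as the target, with stated times of 30 min and 2 h, at a dose of 10 mg/kg by the intraperitoneal route (a higher number here means more inhibition at the dose given (going by the name of the read-out), a lower number less inhibition), compound 1 gives 40%. Compound 2 `O=C(NCc1ccc(CNS(=O)(=O)c2ccccc2)cc1)c1cccnc1` carries a pyridin-3-yl, and in this assay compound 2 gives 53%; the step of a number 13 percentage points higher from compound 1 to compound 2 (beyond the scatter) is the only measured step among these compounds. Compound 3 `O=C(NCc1ccc(CNS(=O)(=O)c2ccccc2)cc1)c1c(Cl)cc(Cl)cc1Cl` carries a 2,4,6-trichlorophenyl, and in this assay compound 3 is reported as "not active" (no number reported), so no number stands for it and it cannot be placed against the others beyond that.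

Compound 4 `O=C(NCc1ccc(CNS(=O)(=O)c2ccccc2)cc1)c1ccccc1` differs from compound 3 in one place: phenyl in place of 2,4,6-trichlorophenyl on a carbonyl carbon. Within the data shown here, no measured step bears directly on this change; the only measured step exchanges one six-membered ring for another of similar size and moves the read-out modestly. Compound 3 is reported without a number, while compound 4 differs in its ring from compound 1 by a single fluorine, and compound 1 gives 40%. On that ground compound 4 is expected to land near compound 1 or somewhat lower, with wide uncertainty. In this assay compound 4 is estimated at 33%, expected to fall between 8% and 58%.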

Compound 4, a percentage reported as inhibition, in the whole organism at one dose (the size of the read-out at that dose, not a potency): 62%
Beside the measured number, compound 4's estimate is 29 percentage points below it; the measured number lies above the stated range.
By their numbers in this assay, from the lowest: compound 1; then compounds 2 and 4 (each within the scatter of the next).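

Compound 4 shows that the carbonyl carbon can carry a bare phenyl and still give a clear reading in this assay: with the 2,4,6-trichlorophenyl, compound 3 is reported as "not active" (no number reported) and no number stands for it, whereas with phenyl in its place compound 4 gives 62% in the same assay. It also shows that one substituent on this ring counts, since hydrogen in place of fluoro on an aromatic carbon gives a number 22 percentage points higher from compound 1 to compound 4 (beyond the scatter), while phenyl in place of pyridin-3-yl gives only a number 9 percentage points higher from compound 2 to compound 4 (within the scatter) and so does not separate these two rings. The data shown offer no measured reason for either difference.

As far as these compounds go, it remains open whether a single chloro or a methoxy on the phenyl ring would read like compound 1 or like compound 4, as compound 3 carries all three chlorine atoms at once. Also open, from the compounds shown here alone, is whether an aromatic ring is needed on the carbonyl carbon at all, or whether a cyclohexyl, a longer alkyl chain or a chain ending in an amine would hold the reading.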